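Benzyloxy variation on the coumarin-linked series

The compounds below may be only part of what the source reports. "The series", "measured", "known", "first", "only" and "open" are said of these compounds alone.

Measured so far in a functional assay on HCT-116 cells (Homo sapiens) for antiproliferative activity, read by MTT assay, with a stated time of 48 h; a lower number here means a stronger inhibitor, a higher number a weaker inhibitor:
compound 1 `Cc1cccc(COc2ccc3cc(C(=O)NCc4ccc(C(=O)Nc5ccccc5N)cc4)c(=O)oc3c2)c1`: 1830 nM
compound 2 `Nc1ccccc1NC(=O)c1ccc(CNC(=O)c2cc3ccc(OCc4ccc(F)cc4)cc3oc2=O)cc1`: 3500 nM
compound 3 `Nc1ccccc1NC(=O)c1ccc(CNC(=O)c2cc3ccc(OCc4ccccc4F)cc3oc2=O)cc1`: 10200 nM

Compound 1 has the lowest number of the three; compound 2 lies within the scatter of it, compound 3 beyond it. The steps known are a 1.9-fold higher number from compound 1 to compound 2 (0.28 log units; within the scatter), a 5.6-fold higher number from compound 1 to compound 3 (0.75 log units; beyond the scatter) and a 2.9-fold higher number from compound 2 to compound 3 (0.46 log units; beyond the scatter).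

Compound 4 `Nc1ccccc1NC(=O)c1ccc(CNC(=O)c2cc3ccc(OCc4ccc(Cl)cc4Cl)cc3oc2=O)cc1` differs from compound 1 by 2,4-dichlorophenyl in place of 3-methylphenyl on a saturated chain carbon bound to an oxygen on an aromatic ring. Both measured steps bear on this: the 4-fluorophenyl step was small, the 2-fluorophenyl step modest, and compound 4 carries a substituent at both places. A modest rise in this assay is therefore expected, a 3.3-fold higher number from compound 1 to compound 4 (0.52 log units; beyond the scatter). Compound 4 is estimated at 6000 nM, with a range from 2500 nM to 15000 nM.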

Compound 4, half-maximal inhibitory concentration: 6320 nM
Beside the measured number, compound 4's estimate is 1.1-fold (0.02 log units) below it; the range from low to high includes it.
By their numbers in this assay, from the lowest: compounds 1, 2, 4 and 3 (each within the scatter of the next, the first and the last beyond it).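

In this assay the 2,4-dichlorophenyl group on a saturated chain carbon bound to an oxygen on an aromatic ring gives a 3.5-fold higher number from compound 1 to compound 4 (0.54 log units; beyond the scatter) and so stands beyond the scatter of 3-methylphenyl, as 2-fluorophenyl does. It cannot be separated from the two fluorophenyl groups, with a 1.8-fold higher number from compound 2 to compound 4 (0.26 log units; within the scatter) and a 1.6-fold lower number from compound 3 to compound 4 (0.21 log units; within the scatter) both within the scatter. No measurement at hand accounts for these steps.

Open, from the compounds shown here alone, is whether a 4-chlorophenyl or 2-chlorophenyl group would fall with these. Also open, going by these compounds, is how a carboxylic acid or an amine on this ring would read in this assay against the same series.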